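Cyclopropyl Amide in a Series of Weak Cytotoxic Agents

The source may report more compounds than this note shows. Statements on the series, on what has been measured and on what is new or still open speak of the compounds shown alone.

Compound 1 `CNC(=O)Cn1nc(N)c2c(C(F)(F)F)cc(-c3ccccc3)nc21` was tested in a functional assay on DU-145 cells (Homo sapiens) for cytotoxicity, read by MTT assay, with a stated time of 24 h (a higher number here means a weaker inhibitor, a lower number a stronger inhibitor), where compound 1 gives 14400 nM, the lowest of the three numbers recorded. In this assay compound 2 `CCNC(=O)Cn1nc(N)c2c(C(F)(F)F)cc(-c3ccccc3)nc21` gives 17900 nM, and compound 3 `NNC(=O)Cn1nc(N)c2c(C(F)(F)F)cc(-c3ccccc3)nc21` gives 52400 nM. The step of a 1.2-fold higher number from compound 1 to compound 2 (0.09 log units; within the scatter) lies within the scatter, whereas a 3.6-fold higher number from compound 1 to compound 3 (0.56 log units; beyond the scatter) and a 2.9-fold higher number from compound 2 to compound 3 (0.47 log units; beyond the scatter) are modest and beyond it. Compound 4 `Nc1nn(CC(=O)NC2CC2)c2nc(-c3ccccc3)cc(C(F)(F)F)c12` differs from compound 1 by cyclopropyl in place of methyl on an amide-type nitrogen. Going by the values given here, only the step from compound 1 to compound 2, which also enlarges the group on the amide-type nitrogen, bears on this change, and it moved nothing beyond the scatter. Compound 4 is therefore expected to give about 15000 nM, with a range of 7000 nM to 35000 nM. The expected step is a 1.0-fold higher number from compound 1 to compound 4 (0.02 log units; within the scatter).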

Compound 4, half-maximal inhibitory concentration: "not active" (no number reported)
The entry for compound 4 holds no number; the estimate stays without a comparison.
By their numbers in this assay, from the lowest: compounds 1 and 2 (each within the scatter of the next); then compound 3.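

Going by these compounds alone, compound 4 is recorded as "not active" without a number, and no step from compound 1 to compound 4 can be read. Nothing shown accounts for this entry. Going by these compounds, how far cyclopropyl in place of methyl on an amide-type nitrogen shifts the number in this assay stays open.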